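Cytotoxicity notes: varying the ether on the pendant phenyl

The source may hold more compounds than are shown below. What is called first, only, known or untested is meant among the compounds shown, and "the series" means these compounds.

Measured compounds:
- compound 1, `O=c1cc(-c2ccccc2O)oc2cc(OCCCCCCCCN3CCCC3)ccc12`: 60.6%
- compound 2, `COc1ccccc1-c1cc(=O)c2ccc(OCCCCCCCCN3CCCC3)cc2o1`: 24.3%

In an ADME assay on HepG2 cells (Homo sapiens) for cytotoxicity, read by MTT assay, with a stated time of 48 h, tested at 10 uM (on this read-out lower numbers stand for a weaker effect and higher numbers for a stronger effect at the one concentration tested), compound 1 gives 60.6%. In this assay compound 2 gives 24.3%, the lower of the two numbers. For the measured compounds named here, the one measured step, a number 36.3 percentage points lower from compound 1 to compound 2 (beyond the scatter), is the only guide. Compound 3, `O=c1cc(-c2ccccc2OCc2ccccc2)oc2cc(OCCCCCCCCN3CCCC3)ccc12`, differs from compound 2 by phenyl in place of hydrogen on a saturated chain carbon bound to an oxygen on an aromatic ring. Going by the values given here, no measured step covers this change; both compounds 2 and 3 lack the free hydroxyl of compound 1, so a large further drop seems unlikely, but the direction is open. The expected step is a number 5.7 percentage points higher from compound 2 to compound 3 (within the scatter). Compound 3 is estimated at 30%, within 10% to 55%.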

Compound 3, a percentage reported as inhibition, at one concentration (the size of the read-out at that concentration, not a potency): 34.1%
Compound 3: the middle estimate sits 4.1 percentage points below what was measured, within the range that was stated.
By their numbers in this assay, from the lowest: compounds 2 and 3 (each within the scatter of the next); then compound 1.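

In this assay, methyl to benzyl on the ether gives a number 9.8 percentage points higher from compound 2 to compound 3 (within the scatter), so methoxy and benzyloxy are not told apart here. Benzyl in place of hydrogen on the oxygen gives a number 26.5 percentage points lower from compound 1 to compound 3 (beyond the scatter), which shows that compound 1 stands apart from a second, larger ether as well as from the methoxy of compound 2. No data at hand bear on the reason for these numbers. Still open, from the compounds shown here alone, is how an amine or a carboxylic acid would read in place of the hydroxyl of compound 1. Also open, going by these compounds, is whether the gap between hydroxyl and ether persists with a longer chain carrying the pyrrolidine.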